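The source may hold more compounds than are shown below. What is called first, only, known or untested is meant among the compounds shown, and "the series" means these compounds.

Working notes on the series, all read in an ADME assay on HUVEC cells (Homo sapiens) for inhibition, read by CCK-8 assay, with a stated time of 24 h, in the presence of a further agent that is not named here; on this read-out lower numbers stand for stronger inhibition and higher numbers for weaker inhibition. Compound 1 `Cc1cccc(-n2cc(-c3ccc(/C=C4\C(=O)Nc5ccccc54)cc3)nn2)c1` gives 13700 nM, and compound 3 `Cc1cccc(-n2cc(-c3ccc(/C=C4\C(=O)Nc5ccc(F)cc54)cc3)nn2)c1` gives 9880 nM. Within the data shown here, these are the only two numbers so far, and they lie within the scatter of each other, so neither ranks above the other. Compound 2 `N#Cc1ccc(-n2cc(-c3ccc(C=C4C(=O)Nc5ccccc54)cc3)nn2)cc1` reads > 20000 nM, which is a limit of the assay and not a number.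

Compound 4 `O=C1Nc2ccc(F)cc2/C1=C/c1ccc(-c2cn(-c3cccc(F)c3)nn2)cc1` differs from compound 3 in one place: fluoro in place of methyl on an aromatic carbon. In words, this is fluoro in place of methyl on an aromatic carbon, meta to a large group, or 3-methylphenyl to 3-fluorophenyl.

Among the measured compounds shown here, only one measured step in a single place is available: a 1.4-fold lower number from compound 1 to compound 3 (0.14 log units; within the scatter). It also brings in a fluoro, but it replaces a hydrogen and leaves the 3-methylphenyl group untouched, so it bears on the change only indirectly. Compound 2 also lacks the methyl, but its limit gives no step size. For the measured compounds named here, no measured step therefore points to a shift beyond the scatter in this assay, and the direction stays open. The expected 1.2-fold higher number from compound 3 to compound 4 (0.08 log units; within the scatter) is small and within the scatter, anchored on the value of compound 3 at 9880 nM. For compound 4 the estimated value is 12000 nM, with an expected range of 5000 nM to 20000 nM.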

Compound 4, half-maximal inhibitory concentration: 17300 nM
Beside the measured number, compound 4's estimate is 1.4-fold (0.16 log units) below it; low and high end bracket the measured number.
By their numbers in this assay, from the lowest: compounds 3, 1 and 4 (each within the scatter of the next). At a limit, above all of these: compound 2.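

In this assay, among these compounds, the exchange of methyl for fluoro, 3-methylphenyl to 3-fluorophenyl, gives the first direct reading at this position on the aromatic ring: a 1.8-fold higher number from compound 3 to compound 4 (0.24 log units; within the scatter). The methyl is therefore not shown to be needed for the read-out, since fluoro in its place leaves compound 4 within the scatter of compound 3, and the two single-place steps shown, this one and the fluoro on the core, both stay within the scatter. Compound 4 still reads as a number and not as a limit, and this series does reach a ceiling of the read-out: the limit of > 20000 nM in this assay, at which 1 of the 4 values shown sits.

As far as these compounds go, whether this position responds at all stays open, as the methyl and fluoro readings do not separate, and a group of another kind here, such as an amine or a carboxylic acid, could test that more sharply. Also open, from the compounds shown here alone, is whether the same 3-methylphenyl to 3-fluorophenyl change reads alike on the core of compound 1, which lacks the fluoro of compound 3.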